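Adding fluoro to the lowest-number compound

The source may hold more compounds than are shown below. What is called first, only, known or untested is meant among the compounds shown, and "the series" means these compounds.

Values measured in a functional assay on MDA-MB-231 cells (Homo sapiens) for antiproliferative activity, read by WST assay, with a stated time of 72 h; a higher number here means a weaker inhibitor of growth, a lower number a stronger inhibitor of growth
- Compound 1 `N=C(N)c1ccc(/N=N/Nc2cccc(C#Cc3ccccn3)c2)cc1` gives 14400 nM
- Compound 2 `N=C(N)c1ccc(/N=N/Nc2ccccc2C#Cc2ccccc2)cc1` gives 5100 nM
- Compound 3 `C#Cc1ccc(N/N=N/c2ccc(C(=N)N)cc2)cc1` gives 30200 nM

Compound 2 has the lowest number of the three, and compound 1 and compound 3 both lie beyond the usual scatter from it. Compound 4 `N=C(N)c1ccc(/N=N/Nc2ccccc2C#Cc2ccc(F)cc2)cc1` changes compound 2 in one place, fluoro in place of hydrogen on an aromatic carbon with fluoro in place of hydrogen on an aromatic carbon, turning phenyl into 4-fluorophenyl. Among the compounds with values here, no measured pair here shows a single change, so the expectation rests on compound 2 at 5100 nM alone. In this assay the expected 1.1-fold lower number from compound 2 to compound 4 (0.03 log units; within the scatter) stays within the scatter, with no firm direction. For compound 4 the estimate is 4800 nM with an expected range from 2100 nM to 11000 nM overall.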

Compound 4, concentration for 50% growth inhibition: 6200 nM
For compound 4 the middle estimate is 1.3-fold (0.11 log units) below the measured one; the measured number falls inside the stated range.
By their numbers in this assay, from the lowest: compounds 2 and 4 (each within the scatter of the next); then compound 1; then compound 3.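

In this assay, within the data shown here, turning phenyl into 4-fluorophenyl gives a 1.2-fold higher number from compound 2 to compound 4 (0.08 log units; within the scatter), the first single change that can be read in this set. Among these compounds, a fluoro at this place, para to a large group, therefore leaves the number within what repeated measurements would show, and the earlier compounds, which differ in more than one place, could not show this. No supporting evidence is available to explain this result.

On these data alone, whether an amine, a carboxylic acid or a methoxy group at the same place would move the number beyond the scatter remains open.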